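Working notes: replacing the 2-phenylphenyl group of compound 2

The source may report more compounds than this note shows. Statements on the series, on what has been measured and on what is new or still open speak of the compounds shown alone.

- compound 1 `C=C(c1cccc2ccccc12)C1CCC2(CC1)COC(Nc1ccc(Cl)cc1)OO2` with 6.15
- compound 2 `C=C(c1cccc2ccccc12)C1CCC2(CC1)COC(Nc1ccccc1-c1ccccc1)OO2` with 7.26

Among the measured compounds shown here, these values come from a physicochemical assay for lipophilicity (on this read-out lower numbers stand for lower lipophilicity and higher numbers for higher lipophilicity), and compound 2 with 7.26 is the higher of the two numbers so far, well clear of compound 1 beyond the scatter. Next in line is compound 3 `C=C(c1cccc2ccccc12)C1CCC2(CC1)COC(Nc1cccc(C(F)(F)F)c1)OO2` which has no measurement yet. The change is 3-(trifluoromethyl)phenyl in place of 2-phenylphenyl on an amine nitrogen and the shared core stays as it is.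

For the measured compounds named here, one measured step bears on this: a number 1.11 log units higher from compound 1 to compound 2 (beyond the scatter) at the same place, with 2-phenylphenyl entering in place of 4-chlorophenyl. Compound 3 gives up that same 2-phenylphenyl group and carries a substituted phenyl, as compound 1 does. A drop of similar size is therefore expected in this assay towards compound 1 at 6.15 as the nearest reference. Going by the values given here, no measured step covers the 3-(trifluoromethyl)phenyl group itself, and the range is kept wide. The expected change is a number 0.86 log units lower from compound 2 to compound 3 (beyond the scatter) and it is a large one. For compound 3 the estimated value is 6.4 with an expected range from 5.8 to 7 for the coming measurement.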

Compound 3, partition coefficient: 6.51
Beside the measured number, compound 3's estimate is 0.11 log units below it; the measured number falls inside the stated range.
By their numbers in this assay, from the lowest: compound 1; then compound 3; then compound 2.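

In this assay, the 2-phenylphenyl group on the amine nitrogen now stands against two single-ring groups rather than one: 3-(trifluoromethyl)phenyl in place of 2-phenylphenyl gives a number 0.75 log units lower from compound 2 to compound 3 (beyond the scatter) and compound 2 keeps the highest number of the three, with both of its steps beyond the scatter. Among the compounds shown here, the single-ring groups are also not interchangeable at this place, since 3-(trifluoromethyl)phenyl in place of 4-chlorophenyl gives a number 0.36 log units higher from compound 1 to compound 3 (beyond the scatter) and this step is smaller than the one from compound 2, so the substituent on a single phenyl ring moves the number as well as the change from two aromatic rings to one. No measured information on the series accounts for either step.

Compounds 1 and 3 differ in both the substituent and where it is named on the ring, so these three compounds cannot separate the two, and the unsubstituted phenyl group is missing as a common reference. As far as these compounds go, how the read-out responds to a phenyl ring carrying an amine or a carboxylic acid, or to a pyridine ring at the same amine nitrogen, remains open.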